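Nitro for Methyl at the Piperazine Phenyl Ring

The source may report more compounds than this note shows. Statements on the series, on what has been measured and on what is new or still open speak of the compounds shown alone.

In a functional assay on the whole organism (Abdomen, strain Swiss) for inhibition, with Mus musculus as the target, with stated times of 30 min, 10 min and 5 min, at a dose of 40 mg/kg by the oral route (on this read-out lower numbers stand for a weaker effect and higher numbers for a stronger effect at the one dose given), three compounds of a shared core have numbers. Compound 1 `CC(=O)c1cccn1CCCN1CCN(c2ccc(F)cc2)CC1` gives 38%, compound 2 `CC(=O)c1cccn1CCCN1CCN(c2cccc(Cl)c2)CC1` gives 54%, and compound 3 `CC(=O)c1cccn1CCCN1CCN(c2ccc(C)cc2)CC1` gives 9%, the lowest of the three. The step of a number 29 percentage points lower from compound 1 to compound 3 (beyond the scatter) and the step of a number 45 percentage points lower from compound 2 to compound 3 (beyond the scatter) both run downward to compound 3, and both lie beyond the scatter.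

Compound 4 `CC(=O)c1cccn1CCCN1CCN(c2ccc([N+](=O)[O-])cc2)CC1` differs from compound 3 in one place: nitro in place of methyl on an aromatic carbon. For the measured compounds named here, no measured compound carries a nitro group, so no step tells directly what this change does. The two steps that bear on it, a number 29 percentage points lower from compound 1 to compound 3 (beyond the scatter) and a number 45 percentage points lower from compound 2 to compound 3 (beyond the scatter), show that exchanging the group on the phenyl ring of the amine nitrogen in a ring moves this assay by modest to large amounts, and that methyl sits at the bottom. Replacing methyl with nitro is therefore expected to move the number upward, toward the level of compound 1, as the step of a number 26 percentage points higher from compound 3 to compound 4 (beyond the scatter) estimated here. Compound 4 is estimated at 35%, with a range from 10% to 62%.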

Compound 4, a percentage reported as inhibition, in the whole organism at one dose (the size of the read-out at that dose, not a potency): 0%
Compound 4: middle estimate off by 35 percentage points, on the high side; the measured number lies below the stated range.
By their numbers in this assay, from the lowest: compounds 4 and 3 (each within the scatter of the next); then compound 1; then compound 2.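

In this assay, nitro in place of methyl on an aromatic carbon, para to a large group, gives a number 9 percentage points lower from compound 3 to compound 4 (within the scatter) and so leaves no difference that can be read between these two groups at this position, although nitro brings more heavy atoms and hydrogen-bond acceptors that methyl lacks. Set against fluoro at the same place, the change gives a number 38 percentage points lower from compound 1 to compound 4 (beyond the scatter), so among the three groups seen at this position fluoro alone stands clear of the other two, which read alike. Nothing available on these compounds accounts for this result.

From the compounds shown here alone, whether an amine or a methoxy group at this place would read with fluoro or with methyl and nitro stays open. So does the reading of a carboxylic acid there.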